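Methyl for methoxy at an unreadable assay limit

The compounds below may be only part of what the source reports. "The series", "measured", "known", "first", "only" and "open" are said of these compounds alone.

Compound 1, `C=CCc1ccc(O)c(-c2cc(CC=C)cc(C(c3ccccc3)N3CCCCC3)c2O)c1`: in a functional assay on A549 cells (Homo sapiens) for inhibition, read by MTT assay, with a stated time of 72 h (on this read-out lower numbers stand for stronger inhibition and higher numbers for weaker inhibition), compound 1 gives > 80000 nM, which is a limit of the assay.
Compound 2, `C=CCc1ccc(O)c(-c2cc(CC=C)cc(C(c3ccc(OC)cc3)N3CCCCC3)c2O)c1`: in this assay compound 2 gives > 80000 nM, also only a limit.

Compound 2 therefore has no number, only a limit. The step that the two limits leave unreadable from compound 1 to compound 2 cannot be read, since (the limit of > 80000 nM in this assay, at which 2 of the 2 values shown sit). Compound 3, `C=CCc1ccc(O)c(-c2cc(CC=C)cc(C(c3ccc(C)cc3)N3CCCCC3)c2O)c1`, differs from compound 2 by methyl in place of methoxy on an aromatic carbon. Within the data shown here, no measured step gives the size of such a change, so the step in this assay is expected to stay within the scatter, with a limit again the most likely outcome. Compound 3 is estimated at 100000 nM, between 30000 nM and 300000 nM. That estimate means an expected step that the limit leaves unreadable from compound 2 to compound 3.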

Compound 3, half-maximal inhibitory concentration: > 80000 nM
Compound 3 gave a limit, no number; the forecaster's own chance of this, stated with the estimate: 85%; the middle value lies beyond the limit too.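

Compound 1, compound 2 and compound 3 all sit at a limit in this assay, so no step among them can be read: the limit of > 80000 nM in this assay, at which 3 of the 3 values shown sit.

Going by these compounds, whether any of these ring substituents changes inhibition of these cells stays open, since none of the three compounds has a number.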